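Swapping the Difluorophenyl for Phenyl: One Step Repeated

The source may hold more compounds than are shown below. What is called first, only, known or untested is meant among the compounds shown, and "the series" means these compounds.

Measured in a functional assay on the whole organism (strain Swiss albino) for inhibition, with Mus musculus as the target, in the writhing test, with a stated time of 30 min, at a dose of 20 mg/kg by the oral route; on this read-out higher numbers stand for a stronger effect at the one dose given and lower numbers for a weaker effect:
Compound 1, `Cc1c(C=O)cc(-c2ccc(S(C)(=O)=O)cc2)n1-c1ccc(F)c(F)c1`, gives 52%.
Compound 2, `Cc1c(C=O)cc(-c2ccc(S(C)(=O)=O)cc2)n1-c1ccccc1`, gives 32%.
Compound 3, `Cc1c(C#N)cc(-c2ccc(S(C)(=O)=O)cc2)n1-c1ccc(F)c(F)c1`, gives 38%.

All three share a five-membered aromatic core; compound 4, `Cc1c(C#N)cc(-c2ccc(S(C)(=O)=O)cc2)n1-c1ccccc1`, has not yet been measured. Compound 4 stands to compound 3 as compound 2 stands to compound 1: the change is phenyl in place of 3,4-difluorophenyl on an aromatic nitrogen. In the measured pair that change gave a number 20 percentage points lower from compound 1 to compound 2 (beyond the scatter). The cores of the two pairs differ by cyano in place of formyl on an aromatic carbon, which itself gave a number 14 percentage points lower from compound 1 to compound 3 (beyond the scatter). Since the group two ring bonds away is a formyl group in one pair and a cyano group in the other, the two swaps are the same kind of change rather than the same change. For the measured compounds named here, with only a single measured instance, the expectation is that the swap behaves about as it did before, so a step of a number 20 percentage points lower from compound 3 to compound 4 (beyond the scatter) is expected from compound 3 to compound 4, resting on a number 20 percentage points lower from compound 1 to compound 2 (beyond the scatter). Compound 4 is therefore estimated to give 18% in this assay, with a plausible range from 5% to 32%.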

Compound 4, a percentage reported as inhibition, in the whole organism at one dose (the size of the read-out at that dose, not a potency): 42%
The estimate for compound 4 lay 24 percentage points below the measured number; measured number outside the range, above it.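

In this assay, phenyl in place of 3,4-difluorophenyl gave a number 4 percentage points higher from compound 3 to compound 4 (within the scatter), so the clear drop seen on the formyl core did not reappear on the cyano core: the same change on two cores in this assay, a number 20 percentage points lower (beyond the scatter) from compound 1 to compound 2 and a number 4 percentage points higher (within the scatter) from compound 3 to compound 4, 24 percentage points apart, beyond the scatter of two such steps. Read along the other edge of the same four compounds, cyano in place of formyl gave a number 10 percentage points higher from compound 2 to compound 4 (within the scatter), and this step also fails to match its earlier counterpart: the same change on two cores in this assay, a number 14 percentage points lower (beyond the scatter) from compound 1 to compound 3 and a number 10 percentage points higher (within the scatter) from compound 2 to compound 4, 24 percentage points apart, beyond the scatter of two such steps. This shows that, in this small set, the effect of one change depends on the group present at the other place, so the two effects cannot simply be added, but it does not show why, or whether the same holds for any other compounds or at any other dose.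

The compounds shown leave open how a chlorophenyl or a benzyl group on the aromatic nitrogen would behave with each of the two cores. They also leave open what an amide or a carboxylic acid would do in the place held by the formyl and cyano groups.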